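Acetyl in Place of Hydrogen on Compound 2

A few compounds are considered here, and "the series" means these few. Any claim that something is new, unique, unknown or untested is made for them only; others in the source may bear on it.

Measured so far:
compound 1 `O=C(Nc1nc(-c2ccccc2)nc2cn(-c3ccccc3)nc12)c1ccco1` gives 24 nM in an assay on CHO cells for displacement of a labelled ligand from adenosine receptor A3 (Homo sapiens), read by scintillation counting, with a stated time of 60 min; a higher number here means a weaker inhibitor, a lower number a stronger inhibitor
compound 2 `COc1ccc(-n2cc3nc(-c4ccccc4)nc(N)c3n2)cc1` gives 75 nM in this assay
compound 3 `CC(=O)Nc1nc(C)nc2cn(-c3ccccc3)nc12` gives 300 nM in this assay

Among these three numbers compound 2 stands second highest: compound 1 lies lower and compound 3 higher, both gaps beyond the usual scatter. Compound 4 `COc1ccc(-n2cc3nc(-c4ccccc4)nc(NC(C)=O)c3n2)cc1` is not yet measured. It differs from compound 2 in one place: acetyl in place of hydrogen on a nitrogen on an aromatic ring. Among the measured compounds shown here, no pair of measured compounds differs by exactly this change, so its size cannot be read off. Compound 1 and compound 3, both carrying an amide where compound 2 has a free amine, sit on either side of compound 2, so the direction is only a guess. A modest step toward a lower number in this assay is expected, namely a 1.9-fold lower number from compound 2 to compound 4 (0.27 log units; within the scatter). Compound 4 is estimated at 40 nM, with a range from 10 nM to 160 nM.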

Compound 4, inhibition constant: 98 nM
Compound 4: middle estimate off by 2.5-fold (0.39 log units), on the low side; measured number inside the range.
By their numbers in this assay, from the lowest: compound 1; then compounds 2 and 4 (each within the scatter of the next); then compound 3.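

In this assay, among the compounds shown here, the change from amino to acetamido gives a 1.3-fold higher number from compound 2 to compound 4 (0.12 log units; within the scatter), the first direct reading of this change. On this core, the nitrogen on the aromatic ring can therefore carry an acetyl in place of hydrogen with no clear shift in the number.

Still open, from the compounds shown here alone, is whether a longer acyl chain such as butanoyl, or a benzoyl group, on this nitrogen would also leave the number within the scatter. Nothing shown here offers an explanation for this result.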